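Oxidation at the ring sulfur: compound 2 to compound 4

The source may report more compounds than this note shows. Statements on the series, on what has been measured and on what is new or still open speak of the compounds shown alone.

Compound 2 `CCCCCSc1nnc(COc2cc(C)c3c(C)cc(=O)oc3c2)o1` gives in a functional assay on MCF7 cells (Homo sapiens) for antiproliferative activity, read by MTT assay, with a stated time of 24 h (a lower number here means a stronger inhibitor, a higher number a weaker inhibitor), only a limit, > 100000 nM, so no number stands for it. Compound 1 `CCCSc1nnc(COc2cc(C)c3c(C)cc(=O)oc3c2)o1` likewise reaches only the limit > 100000 nM. Compound 3 `Cc1cc(OCc2nnc(SCc3ccc(Cl)cc3Cl)o2)cc2oc(=O)cc(C)c12` gives the other limit, < 5000 nM. The step that the two limits leave unreadable from compound 1 to compound 2 is unreadable because the limit of > 100000 nM in this assay, at which 2 of the 3 values shown sit, holds both ends. The step of an at least 20-fold lower number from compound 2 to compound 3 (1.30 log units; beyond the scatter) is large and bounded by the limit of < 5000 nM in this assay, at which 1 of the 3 values shown sits. Compound 4 `CCS(=O)(=O)c1nnc(COc2cc(C)c3c(C)cc(=O)oc3c2)o1` carries ethylsulfonyl in place of pentylsulfanyl on an aromatic carbon. Neither measured step covers a change at the sulfur itself: the readable gain came with a 2,4-dichlorophenyl group, and chain length alone gave no readable movement. Compound 4 is therefore expected to stay near the limit, the step of a number no higher from compound 2 to compound 4 (the limit leaves the size open) expected to be small, with an estimate of 100000 nM (30000 nM to 300000 nM).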

Compound 4, half-maximal inhibitory concentration: > 100000 nM
Compound 4 ended at the assay's limit (the forecaster's own chance of this, stated with the estimate: 70%); the middle value lies on the limit itself.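

In this assay, the change at the sulfur itself leaves compound 4 at a limit of the assay and not at a number: > 100000 nM. The steps to compound 4 from compound 1 and compound 2 cannot be read: the limit of > 100000 nM in this assay, at which 3 of the 4 values shown sit.

Ethylsulfonyl in place of (2,4-dichlorobenzyl)sulfanyl gives an at least 20-fold higher number from compound 3 to compound 4 (1.30 log units; beyond the scatter), the only readable step here, but it alters the sulfur and the group on it together and cannot separate the two.

As far as these compounds go, whether a (2,4-dichlorobenzyl)sulfonyl group would stay off the upper limit remains open. So does the outcome for an amine or a carboxylic acid on this aromatic carbon.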